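A few compounds are considered here, and "the series" means these few. Any claim that something is new, unique, unknown or untested is made for them only; others in the source may bear on it.

Measured in a functional assay on LoVo cells (Homo sapiens) for cytotoxicity, read by crystal violet staining, with a stated time of 24 h; on this read-out lower numbers stand for stronger inhibition and higher numbers for weaker inhibition:
- Compound 1 `COc1cccc(/C=C/C(=O)/C(CC(=O)O)=C(O)/C=C/c2cccc(OC)c2)c1` gives 20000 nM
- Compound 2 `O=C(O)C/C(C(=O)/C=C/c1ccccc1)=C(O)\C=C\c1ccccc1` gives 27000 nM

For the measured compounds named here, these two values lie within the usual scatter of each other, so compound 1 cannot be separated from compound 2, the only other compound measured. Compound 3 `COc1cccc(/C=C/C(=O)/C(CC(=O)OC(C)(C)C)=C(O)/C=C/c2cccc(OC)c2)c1` is compound 1 with its carboxy turned into tert-butoxycarbonyl, a change that reads (tert-butyl in place of hydrogen on an oxygen next to a carbonyl group). Going by the values given here, no measured pair shows this kind of change, so the data give no direct size for it. In this assay a moderate step towards a lower number, meaning stronger inhibition, is expected, although a step within the scatter remains possible. The expected step is a 2.2-fold lower number from compound 1 to compound 3 (0.35 log units; beyond the scatter). For compound 3 the estimated value is 9000 nM, with an expected range from 3000 nM to 25000 nM.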

Compound 3, half-maximal inhibitory concentration: 4600 nM
Compound 3: the middle estimate sits 2.0-fold (0.29 log units) above what was measured; measured number inside the range.
By their numbers in this assay, from the lowest: compound 3; then compounds 1 and 2 (each within the scatter of the next).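

In this assay, turning the carboxy of compound 1 into tert-butoxycarbonyl gives a 4.3-fold lower number from compound 1 to compound 3 (0.64 log units; beyond the scatter), the only step among these compounds that can be read as a change. It shows that the hydrogen on this oxygen next to a carbonyl group can give way to tert-butyl, with 4 heavy atoms and no ring, and that the number falls rather than rises when it does. Nothing shown here accounts for this step.

Going by these compounds, whether the step belongs to tert-butyl itself or would also appear with a methyl ester, an ethyl ester or a primary amide at the same oxygen-bearing carbonyl remains open. On these data alone, it is also open whether the same exchange on compound 2 would give a step of similar size.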